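What One Amino Group May Do for Compound 3

A few compounds are considered here, and "the series" means these few. Any claim that something is new, unique, unknown or untested is made for them only; others in the source may bear on it.

Compound 1 `COc1cc(OC)c(Cl)c(-c2ccc3c(NC(=O)c4ccc(N5CCN(C)CC5)cc4)n[nH]c3n2)c1Cl`: 1.7 nM
Compound 2 `C=CCN1CCN(c2ccc(C(=O)Nc3n[nH]c4nc(-c5c(Cl)c(OC)cc(OC)c5Cl)ccc34)cc2)CC1`: 3.3 nM
Compound 3 `COc1cc(OC)c(Cl)c(-c2ccc3c(NC(=O)c4ccccc4)n[nH]c3n2)c1Cl`: > 1000 nM

In a functional assay on NCI-H1581 cells (Homo sapiens) for antiproliferative activity, read by CCK-8 assay, with a stated time of 72 h (on this read-out higher numbers stand for weaker inhibition and lower numbers for stronger inhibition), compound 3 gives > 1000 nM, which is a limit of the assay and not a number. The change leading to compound 4 `COc1cc(OC)c(Cl)c(-c2ccc3c(NC(=O)c4ccc(N)cc4)n[nH]c3n2)c1Cl` is small: amino in place of hydrogen on an aromatic carbon. Amino takes the place of hydrogen on an aromatic carbon, para to a large group.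

Within the data shown here, two measured steps bear on this change, since each also concerns hydrogen and a larger group on an aromatic carbon. They are an at least 580-fold higher number from compound 1 to compound 3 (2.76 log units; beyond the scatter) and an at least 300-fold higher number from compound 2 to compound 3 (2.48 log units; beyond the scatter), both large and beyond the scatter. The step of a 1.9-fold higher number from compound 1 to compound 2 (0.29 log units; within the scatter) lies within the scatter. Amino is far smaller than 4-methylpiperazin-1-yl or 4-allylpiperazin-1-yl, so only part of those large steps is expected to return. Stronger inhibition, meaning a lower number, is the expected direction, although compound 4 may still reach only a limit. The expected change is an at least 3.3-fold lower number from compound 3 to compound 4 (0.52 log units; beyond the scatter). For compound 4 the estimated value is 300 nM, with an expected range from 40 nM to 2000 nM.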

Compound 4, half-maximal inhibitory concentration: 218 nM
For compound 4 the middle estimate is 1.4-fold (0.14 log units) above the measured one; the measured number falls inside the stated range.
By their numbers in this assay, from the lowest: compounds 1 and 2 (each within the scatter of the next); then compound 4. At a limit, above all of these: compound 3.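

In this assay, a single amino group on this aromatic carbon, para to a large group, is enough to produce a measurable gain: an at least 4.5-fold lower number from compound 3 to compound 4 (0.66 log units; beyond the scatter). That step gives only a lower bound on the true change, because compound 3 stands at a limit of the assay and not at a number: the limit of > 1000 nM in this assay, at which 1 of the 4 values shown sits. The amino group still recovers only part of what the two piperazine groups provide, with a 66-fold higher number from compound 2 to compound 4 (1.82 log units; beyond the scatter) and a 130-fold higher number from compound 1 to compound 4 (2.11 log units; beyond the scatter).

As far as these compounds go, it remains open whether a dimethylamino group or a morpholine ring on the same carbon would land nearer to compound 4 or nearer to compound 1. Also open, from the compounds shown here alone, is how an amino group would fare on a different carbon of this six-membered ring.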